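The source may report more compounds than this note shows. Statements on the series, on what has been measured and on what is new or still open speak of the compounds shown alone.

In a functional assay on MCF7 cells (Homo sapiens) for inhibition (a lower number here means a stronger inhibitor, a higher number a weaker inhibitor), compound 3 (`COc1ccc(-c2nc3cc(F)ccc3s2)cc1`) gives 490 nM and stands within the scatter of compound 1 (`Oc1ccc(-c2nc3cc(F)ccc3s2)cc1`), which gives 400 nM on the same read-out. Both sit far from compound 2 (`COc1ccc(-c2cc(=O)c3cc(F)ccc3o2)cc1OC`), which gives 83400 nM and has the highest number of the three. Compound 4 (`COc1ccc(-c2nc3cc(F)ccc3s2)cc1F`) differs from compound 3 by a single change (fluoro in place of hydrogen on an aromatic carbon): fluoro in place of hydrogen on an aromatic carbon, ortho to a methoxy group. Going by the values given here, only one measured step bears on this part of the molecule, methyl in place of hydrogen on an oxygen on an aromatic ring, and it amounts to a 1.2-fold higher number from compound 1 to compound 3 (0.09 log units; within the scatter) in all. Among the compounds with values here, no measured step places a fluoro at this position, so the data offer no direction for the change and leave the estimate wide. In this assay the expected outcome is therefore no shift beyond the scatter, and the estimated step is a 1.4-fold lower number from compound 3 to compound 4 (0.15 log units; within the scatter) at its middle. For compound 4 the estimated value is 350 nM (expected range 60 nM to 1300 nM) once it is measured.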

Compound 4, half-maximal inhibitory concentration: 870 nM
Beside the measured number, compound 4's estimate is 2.5-fold (0.40 log units) below it, within the range that was stated.
By their numbers in this assay, from the lowest: compounds 1, 3 and 4 (each within the scatter of the next, the first and the last beyond it); then compound 2.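

In this assay the fluoro, placed ortho to a methoxy group on the aromatic ring, gives a 1.8-fold higher number from compound 3 to compound 4 (0.25 log units; within the scatter) and so leaves no shift that can be told from repeat measurement. Going by these compounds alone, this is the first measured change at this ring carbon, whereas the earlier step of a 1.2-fold higher number from compound 1 to compound 3 (0.09 log units; within the scatter) concerned only the oxygen, and both steps stay within the scatter. No measured evidence bears on why the fluoro has this outcome.

Among the compounds shown, this carbon carries only hydrogen or fluoro, so the outcome with a group such as an amine, a carboxylic acid or a longer chain there remains open. Also open, from the compounds shown here alone, is whether the fluoro would give a similar step with the hydroxy group of compound 1 in place of the methoxy group.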